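Adding a methoxy group to the allyl carbamate analogue

The source may hold more compounds than are shown below. What is called first, only, known or untested is meant among the compounds shown, and "the series" means these compounds.

Compound 1, `CC(C)COC(=O)NS(=O)(=O)Nc1cccc(-c2cc3ccccc3[nH]2)c1`, gives 30000 nM.
Compound 2, `COc1ccc(-c2cc3ccccc3[nH]2)cc1NS(=O)(=O)NC(=O)OCC(C)C`, gives 1450 nM.
Compound 3, `C=CCOC(=O)NS(=O)(=O)Nc1cccc(-c2cc3ccccc3[nH]2)c1`, gives 15400 nM.

All three numbers come from an assay for inhibition of Polyunsaturated fatty acid lipoxygenase ALOX15 (Oryctolagus cuniculus), read by spectrophotometry; a higher number here means a weaker inhibitor, a lower number a stronger inhibitor. Among them compound 3 stands second highest. Its nearest neighbour is compound 1, and the step of a 1.9-fold lower number from compound 1 to compound 3 (0.29 log units; within the scatter) shows that swapping the chain on the carbamate oxygen does little. Compound 2 lies much further away, with a clearly lower number.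

Compound 4, `C=CCOC(=O)NS(=O)(=O)Nc1cc(-c2cc3ccccc3[nH]2)ccc1OC`, has not yet been measured. It differs from compound 3 in one place: methoxy in place of hydrogen on an aromatic carbon. Exactly this change has been seen once before on the same core, in the step of a 21-fold lower number from compound 1 to compound 2 (1.32 log units; beyond the scatter), which was large. Since the chain difference between the two pairs is itself within the scatter, a drop of similar size is expected here, namely a 21-fold lower number from compound 3 to compound 4 (1.31 log units; beyond the scatter). Compound 4 is therefore estimated at 750 nM, with a likely range from 250 nM to 2500 nM.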

Compound 4, half-maximal inhibitory concentration: 630 nM
For compound 4 the middle estimate is 1.2-fold (0.08 log units) above the measured one; the measured number falls inside the stated range.
By their numbers in this assay, from the lowest: compound 4; then compound 2; then compounds 3 and 1 (each within the scatter of the next).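

Among the compounds shown here, with the other carbamate chain, methoxy in place of hydrogen again gives a large change, a 24-fold lower number from compound 3 to compound 4 (1.39 log units; beyond the scatter), so the effect at this position, para to the 1H-indol-2-yl group, no longer rests on a single pair and keeps its size on both cores: the same change on two cores in this assay, a 21-fold lower number (1.32 log units; beyond the scatter) from compound 1 to compound 2 and a 24-fold lower number (1.39 log units; beyond the scatter) from compound 3 to compound 4, 1.2-fold (0.07 log units) apart, within the scatter of two such steps The chain swap, read on the methoxy compounds, gives a 2.3-fold lower number from compound 2 to compound 4 (0.36 log units; beyond the scatter), which is modest and beyond the scatter, and it agrees with the same swap on the compounds without methoxy: the same change on two cores in this assay, a 1.9-fold lower number (0.29 log units; within the scatter) from compound 1 to compound 3 and a 2.3-fold lower number (0.36 log units; beyond the scatter) from compound 2 to compound 4, 1.2-fold (0.07 log units) apart, within the scatter of two such steps Across these four compounds, then, each change has about the same size whether or not the other is present, and no compound goes against this.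

From the compounds shown here alone, whether a hydroxyl group, a chlorine atom or a longer ethoxy chain would act like methoxy here remains open. So does whether methoxy would have the same effect elsewhere on this ring.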